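The source may hold more compounds than are shown below. What is called first, only, known or untested is meant among the compounds shown, and "the series" means these compounds.

Three compounds built on a shared core have been run in a functional assay on PC-3 cells (Homo sapiens) for antiproliferative activity, read by MTT assay, with a stated time of 72 h; on this read-out higher numbers stand for weaker inhibition and lower numbers for stronger inhibition. Compound 1 `O=C(COc1ccc(C(=O)/C=C/c2ccccc2Cl)cc1)N[C@H]1CCOC1=O` is the one of the three that returns a number: in this assay compound 1 gives 4610 nM. Compound 2 `O=C(CNc1cccc(Cl)c1)N[C@H]1CCOC1=O` reaches only the limit of this assay, reported as > 64000 nM. Compound 3 `C=CCc1ccc(OCCSC(=S)N[C@H]2CCOC2=O)c(OC)c1` likewise stops at the limit, reported as > 64000 nM. For the measured compounds named here, compound 1 therefore stands alone as the only measured value, the other two sitting at the limit of > 64000 nM in this assay, at which 2 of the 3 values shown sit, so no ordering among them can be read beyond the fact that compound 1 is the one inhibitor with a number.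

Compound 4 `O=C(COc1ccc(C(=O)/C=C/c2cccc(Cl)c2)cc1)N[C@H]1CCOC1=O` has not yet been measured in this assay. It differs from compound 1 in a single place: 3-chlorophenyl in place of 2-chlorophenyl on a double-bonded chain carbon bound to a double-bonded chain carbon. Going by the values given here, no pair of measured compounds in this set differs in one place, so there is no measured step to set beside this change. The step from compound 1 to compound 4 in this assay is expected to fall within the usual scatter, in no particular direction. Since compound 1 gives 4610 nM, compound 4 is expected to give about 4000 nM, in a range from 1500 nM to 12000 nM. That estimate corresponds to an expected step of a 1.2-fold lower number from compound 1 to compound 4 (0.06 log units; within the scatter).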

Compound 4, half-maximal inhibitory concentration: 4990 nM
Compound 4: the middle estimate sits 1.2-fold (0.10 log units) below what was measured; the measured number falls inside the stated range.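

In this assay, 3-chlorophenyl in place of 2-chlorophenyl on a double-bonded chain carbon bound to a double-bonded chain carbon gives a 1.1-fold higher number from compound 1 to compound 4 (0.03 log units; within the scatter). For the compounds shown here, this is the first step in the set between two compounds that differ in one place, and it shows that this exchange of one chlorophenyl group for the other leaves the read-out within the scatter, so the value of compound 1 is no longer an isolated number and the two compounds cannot be told apart in this assay. Nothing among the data shown gives a reason for this result.

On these data alone, the step speaks only to these two chlorophenyl groups, so it remains open whether the number would hold with an unsubstituted phenyl, or with a phenyl carrying an amine or a carboxylic acid in place of the chlorine. It also remains open how the number would respond if a longer chain replaced the double-bonded chain that carries this ring, since no step shown touches any other place in the structure.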